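This account rests on a few compounds, and the source may have more. Where it says the series, first, only, none or still open, it means among the compounds named here.

Working notes on the series. Compound 1 `O=C(CCCCC1CCSS1)NCc1cn(CCCOc2ccc3cc(-c4ccccc4)c(=O)oc3c2)nn1` gives 27.2% in a functional assay on PC-12 cells (Rattus norvegicus) for cytotoxicity, read by MTT assay, with stated times of 3 h and 2 h, tested at 20 uM; on this read-out lower numbers stand for a weaker effect and higher numbers for a stronger effect at the one concentration tested. Compound 2 `COc1ccc(-c2cc3ccc(OCCCn4cc(CNC(=O)CCCCC5CCSS5)nn4)cc3oc2=O)cc1` gives 62% in this assay, and compound 3 `COc1ccc(-c2cc3ccc(OCCCCCn4cc(CNC(=O)CCCCC5CCSS5)nn4)cc3oc2=O)cc1` gives 49% in this assay. For the measured compounds named here, the one counted change between compound 1 and compound 2 is methoxy in place of hydrogen on an aromatic carbon and it made a step of a number 34.8 percentage points higher from compound 1 to compound 2 (beyond the scatter). The difference between the cores of compound 1 and compound 3 is not broken down here; their two values simply show compound 3 higher.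

Compound 4 `COc1ccc(-c2cc3ccc(OCCCCCn4cc(CNC(=O)CCCCC5CCSS5)nn4)cc3oc2=O)cc1OC` is not yet measured. Its difference from compound 3 is methoxy in place of hydrogen on an aromatic carbon. This is the same kind of change as from compound 1 to compound 2, not the same: there the entering methoxy sat para to a large group, here it sits ortho to a methoxy group and meta to a large group. Because the earlier step of a number 34.8 percentage points higher from compound 1 to compound 2 (beyond the scatter) was large, a rise is expected for compound 4 as well. The place is not the same, and a smaller step is therefore expected. In this assay compound 4 is expected to give 57%, estimated between 38% and 76%. That estimate means an expected step of a number 8 percentage points higher from compound 3 to compound 4 (within the scatter).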

Compound 4, a percentage reported as activity, at one concentration (the size of the read-out at that concentration, not a potency): 51.9%
Estimate against measurement, compound 4: 5.1 percentage points above; the range from low to high includes it.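

Methoxy in place of hydrogen on an aromatic carbon gives, in this assay, a number 2.9 percentage points higher from compound 3 to compound 4 (within the scatter), so compound 4 is not separated from compound 3 on this read-out. The size of the change therefore did not carry over from one core to the other: the same change on two cores in this assay, a number 34.8 percentage points higher (beyond the scatter) from compound 1 to compound 2 and a number 2.9 percentage points higher (within the scatter) from compound 3 to compound 4, 31.9 percentage points apart, beyond the scatter of two such steps This does not show what sets the two steps apart, since they differ both in the core and in the place of the entering methoxy, which in compound 4 stands ortho to a methoxy group and meta to a large group, and two pairs give no rule for any further core.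

Still open, as far as these compounds go, is whether 4-methoxyphenyl to 3,4-dimethoxyphenyl would read the same on the core of compound 2, which would separate the place of the methoxy from the core. Also open, from the compounds shown here alone, is how an amine or a carboxylic acid in place of the entering methoxy would read in this assay.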